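The source may hold more compounds than are shown below. What is called first, only, known or untested is meant among the compounds shown, and "the series" means these compounds.

Measured in a functional assay on VCaP cells (Homo sapiens) for antiproliferative activity, read by propidium iodide staining, with a stated time of 96 h; a higher number here means a weaker inhibitor, a lower number a stronger inhibitor:
- compound 1 `CC(O)(CSc1cccc(S(F)(F)(F)(F)F)c1)C(=O)Nc1ccc(S(F)(F)(F)(F)F)cc1`: 28200 nM
- compound 2 `CC(O)(CSc1ccc(C(F)(F)F)cc1)C(=O)Nc1ccc(S(F)(F)(F)(F)F)cc1`: 24800 nM
- compound 3 `CC(O)(CSc1cccc(C(F)(F)F)c1)C(=O)Nc1ccc(S(F)(F)(F)(F)F)cc1`: 18800 nM

The three compounds form a flat set. In this assay compound 3 gives 18800 nM, and its steps to both neighbours stay within the scatter, so it cannot be separated from either of them.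

Compound 4 `CC(O)(CSc1ccc(C(F)(F)F)cn1)C(=O)Nc1ccc(S(F)(F)(F)(F)F)cc1` departs from compound 3 in one place, with 5-(trifluoromethyl)pyridin-2-yl in place of 3-(trifluoromethyl)phenyl on a sulfur.

Among the measured compounds shown here, two measured steps bear on this change, though only indirectly. The closer one alters the same aromatic group on the sulfur, a 1.3-fold lower number from compound 2 to compound 3 (0.12 log units; within the scatter). The other exchanges a group on an aromatic carbon, a 1.5-fold lower number from compound 1 to compound 3 (0.18 log units; within the scatter). Both are small and within the scatter. No measured compound carries a ring with a hetero atom, so the effect of the ring nitrogen itself is not shown by these data, and the range has to stay wide.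

On the evidence of these two small steps, no change beyond the scatter is expected, and no direction can be argued. The expected step is a 1.2-fold higher number from compound 3 to compound 4 (0.07 log units; within the scatter). Compound 4 is estimated at 22000 nM, with an expected range from 10000 nM to 45000 nM.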

Compound 4, half-maximal inhibitory concentration: 19000 nM
Estimate against measurement, compound 4: 1.2-fold (0.06 log units) above, within the range that was stated.
By their numbers in this assay, from the lowest: compounds 3, 4, 2 and 1 (each within the scatter of the next).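

In this assay the exchange of 3-(trifluoromethyl)phenyl for 5-(trifluoromethyl)pyridin-2-yl on the sulfur gives a 1.0-fold higher number from compound 3 to compound 4 (0.00 log units; within the scatter) and so brings the first ring with a hetero atom into the set, together with a hydrogen-bond acceptor that the earlier aromatic groups on the sulfur do not have. The same ring set against 4-(trifluoromethyl)phenyl gives a 1.3-fold lower number from compound 2 to compound 4 (0.12 log units; within the scatter) and so this position accepts a ring nitrogen without any step that can be told from the scatter, which means that compound 4 joins the flat set and neither of these exchanges separates it from its neighbours. No measurement at hand offers a reason for this flatness, and nothing shows whether the ring nitrogen has any effect of its own on the cells.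

As far as these compounds go, all four compounds keep the same amide part and a fluorinated group on the aromatic ring on the sulfur, so the effect of an amine or a carboxylic acid in place of the trifluoromethyl remains open. Also open, from the compounds shown here alone, is whether a sulfone in place of the sulfur would move the number beyond the scatter in this assay or leave it in the same flat set.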